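This account rests on a few compounds, and the source may have more. Where it says the series, first, only, none or still open, it means among the compounds named here.

Measured so far:
compound 1 `O=C(NCc1cc(C(F)(F)F)nn1-c1ccc(F)c(Cl)c1)Nc1cccc2[nH]ncc12`: 0.6 nM
compound 2 `CC(C)(C)c1cc(CNC(=O)Nc2cccc3[nH]ncc23)n(-c2ccc(C(F)(F)F)cc2)n1`: 19.6 nM

In an assay on CHO-K1 cells for antagonist activity at transient receptor potential cation channel subfamily V member 1 (Homo sapiens), read by FLIPR and calcium flux, with a stated time of 6 min (on this read-out lower numbers stand for stronger inhibition and higher numbers for weaker inhibition), compound 1 gives 0.6 nM, while compound 2 gives 19.6 nM, the higher of the two numbers and well beyond the scatter away from compound 1. Compound 3 `CC(C)(C)c1cc(CNC(=O)Nc2cccc3[nH]ncc23)n(-c2ccc(F)c(Cl)c2)n1` is not yet measured. It differs from compound 2 by one change, (3-chloro-4-fluorophenyl in place of 4-(trifluoromethyl)phenyl on an aromatic nitrogen), the same aromatic ring that compound 1 carries. Among the measured compounds shown here, no measured pair isolates this change, so the size of the step is uncertain. Compound 3 is expected to give a lower number than compound 2, a step of a 3.9-fold lower number from compound 2 to compound 3 (0.59 log units; beyond the scatter) in this assay. The estimate for compound 3 is 5 nM, within a range from 1.2 nM to 20 nM.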

Compound 3, inhibition constant: 0.5 nM
Compound 3: the middle estimate sits 10-fold (1.00 log units) above what was measured; measured number below the stated range.
By their numbers in this assay, from the lowest: compounds 3 and 1 (each within the scatter of the next); then compound 2.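

Placing 3-chloro-4-fluorophenyl in place of 4-(trifluoromethyl)phenyl on the aromatic nitrogen gives a 39-fold lower number from compound 2 to compound 3 (1.59 log units; beyond the scatter) in this assay, so the group at this position has a large effect on the read-out. With 3-chloro-4-fluorophenyl held fixed, tert-butyl in place of trifluoromethyl on the aromatic carbon gives a 1.2-fold lower number from compound 1 to compound 3 (0.08 log units; within the scatter), so the two compounds cannot be told apart. Nothing available explains the size of the ring step.

From the compounds shown here alone, whether the chlorine or the fluorine matters more remains open, since no ring carrying only one of them appears here. Plain phenyl and a phenyl bearing an amine also remain untested among these compounds.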